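This account rests on a few compounds, and the source may have more. Where it says the series, first, only, none or still open, it means among the compounds named here.

Measured compounds:
compound 1 `Cc1ccc(S(=O)(=O)Nc2ccc(C(=O)/C=C/c3ccc([N+](=O)[O-])cc3)cc2)cc1` with 26000 nM
compound 2 `Cc1ccc(S(=O)(=O)Nc2ccc(-c3cc(-c4ccc([N+](=O)[O-])cc4)[nH]c(=S)n3)cc2)cc1` with 36500 nM
compound 3 `Cc1ccc(S(=O)(=O)Nc2ccc(C(=O)/C=C/c3ccccc3)cc2)cc1` with "not active" (no number reported)

In a functional assay on HepG2 cells (Homo sapiens) for cytotoxicity, read by sulforhodamine B assay, with a stated time of 48 h (on this read-out higher numbers stand for weaker inhibition and lower numbers for stronger inhibition), compound 1 gives 26000 nM and compound 2 gives 36500 nM. For compound 3 only "not active" (no number reported) is recorded, so it stands below both with no number to place it. Compound 4 `Cc1ccc(S(=O)(=O)Nc2ccc(C(=O)/C=C/c3ccc(Cl)cc3)cc2)cc1` is to be measured in this assay. The change from compound 3 to compound 4 is chloro in place of hydrogen on an aromatic carbon. Within the data shown here, no measured step follows this change, so the size of the step in this assay cannot be read from the data; a small gain, at most modest beyond the scatter, is the expectation, with a real chance of another inactive call. Compound 4 is expected to give about 45000 nM, within 15000 nM to 150000 nM.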

Compound 4, half-maximal inhibitory concentration: 43300 nM
For compound 4 the middle estimate is 1.0-fold (0.02 log units) above the measured one; the measured number falls inside the stated range.
By their numbers in this assay, from the lowest: compounds 1, 2 and 4 (each within the scatter of the next).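

In this assay a chloro group in place of hydrogen at this position goes with a numbered value for compound 4, where compound 3 carries only a "not active" record, so the size of that step cannot be read. The step of a 1.7-fold higher number from compound 1 to compound 4 (0.22 log units; within the scatter) leaves chloro and nitro at this position not told apart. Nothing available bears on the reason for either observation.

Open, as far as these compounds go, is whether an amine or a methoxy group at this position would also give a number, and whether chloro would match nitro on the core of compound 2.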